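The source may report more compounds than this note shows. Statements on the series, on what has been measured and on what is new or still open speak of the compounds shown alone.

In a functional assay on A 172 cells (Homo sapiens) for cytotoxicity, read by colorimetric assay and MTT assay (a lower number here means a stronger inhibitor, a higher number a weaker inhibitor), compound 1 `COc1ccc(-c2cc3c(OC)cc(OC)cc3n(CC#N)c2=O)cc1` gives 10000 nM. Going by the values given here, compound 2 `COc1ccc(-c2cc3c(OC)cc(OC)cc3n(CC(=O)OCc3ccccc3)c2=O)cc1` gives 10000 nM, which places it level with compound 1, its only measured neighbour. The next structure is compound 3 `COC(=O)CCn1c(=O)c(-c2ccc(OC)cc2)cc2c(OC)cc(OC)cc21`, in which (methoxycarbonyl)methyl takes the place of benzyloxycarbonyl on a saturated chain carbon bound to an aromatic nitrogen: (methoxycarbonyl)methyl in place of benzyloxycarbonyl on a saturated chain carbon bound to an aromatic nitrogen. Cut one bond further out, the same difference reads (benzyloxycarbonyl)methyl to 2-(methoxycarbonyl)ethyl. Among the compounds with values here, only one measured step bears on this change, no change at the digits printed from compound 1 to compound 2 (within the scatter), and it altered the same place without moving the number. That is thin evidence, but it gives no reason to expect a shift beyond the scatter in this assay, in either direction. The expected step is no change at the digits printed from compound 2 to compound 3 (within the scatter). For compound 3 the estimated value is 10000 nM, with an expected range of 5000 nM to 20000 nM.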

Compound 3, half-maximal inhibitory concentration: 10000 nM
The estimate for compound 3 equals the measured number at the digits printed; measured number inside the range.
By their numbers in this assay, from the lowest: compounds 1, 2 and 3 (each within the scatter of the next).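

In this assay putting (methoxycarbonyl)methyl in place of benzyloxycarbonyl gives no change at the digits printed from compound 2 to compound 3 (within the scatter) even though the entering group has fewer heavy atoms, and no ring where the leaving group has one six-membered aromatic ring. Putting the same (methoxycarbonyl)methyl in place of cyano gives no change at the digits printed from compound 1 to compound 3 (within the scatter) and so, on a saturated chain carbon bound to an aromatic nitrogen, these three groups cannot be told apart in this assay even though they differ in size and make-up. No measurement is available that would explain these numbers.

As far as these compounds go, what remains open is whether any group at this place can move the number. A carboxylic acid or an amine on this chain, or a longer chain, might read differently, and changes elsewhere on the shared core are a separate question.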